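The compounds below may be only part of what the source reports. "The series", "measured", "known", "first", "only" and "open" are said of these compounds alone.

Measured compounds:
compound 1 `N#Cc1ccc(O[C@H]2CN(S(=O)(=O)c3ccc(Cl)cc3Cl)C[C@@]2(O)CN)cc1F`: 3.2 h
compound 2 `N#Cc1ccc(O[C@H]2CN(S(=O)(=O)c3ccc(Cl)cn3)C[C@@]2(O)CO)cc1F`: 1.2 h

In an ADME assay on the whole organism (Rattus norvegicus, strain Sprague-Dawley), read by LC-MS, with a stated time of 30 min, at a dose of 1 mg/kg by the intravenous route (a lower number here means that the compound disappears faster, a higher number that the compound lasts longer), compound 1 gives 3.2 h and compound 2 gives 1.2 h. Compound 2 stands lowest of the two numbers; its nearest neighbour is compound 1, whose number is higher by a gap beyond the usual scatter.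

Compound 3 `N#Cc1ccc(O[C@H]2CN(S(=O)(=O)c3ccc(Cl)cn3)C[C@@]2(O)CN)cc1F` has not yet been measured in this assay. It departs from compound 2 by one change: amino in place of hydroxy on a saturated chain carbon bound to a saturated ring carbon. Compound 3 thereby shares its aminomethyl group with compound 1. For the measured compounds named here, no measured pair isolates this change, so its effect is not known from these data. Because compound 1 gives 3.2 h with the same aminomethyl group, a modest rise is expected for compound 3, a 1.7-fold higher number from compound 2 to compound 3 (0.22 log units; within the scatter), one that may not exceed the scatter. The estimate for compound 3 is 2 h, with a range from 1 h to 4 h.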

Compound 3, mean residence time: 2.5 h
Compound 3: the middle estimate sits 1.3-fold (0.10 log units) below what was measured, and the stated range covers the measured number.
By their numbers in this assay, from the lowest: compound 2; then compounds 3 and 1 (each within the scatter of the next).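

In this assay, amino in place of hydroxy on a saturated chain carbon bound to a saturated ring carbon now has a matched pair, and hydroxymethyl to aminomethyl gives a 2.1-fold higher number from compound 2 to compound 3 (0.32 log units; beyond the scatter), a modest step just beyond the scatter. With the aminomethyl group held constant, 5-chloropyridin-2-yl in place of 2,4-dichlorophenyl on a sulfonyl sulfur gives a 1.3-fold lower number from compound 1 to compound 3 (0.11 log units; within the scatter), which lies within the scatter, so this pair shows no clear effect of that change. Nothing in the data explains the rise seen with the aminomethyl group.

From the compounds shown here alone, it remains open whether a methylamino group, a longer chain carrying the amine, or a carboxylic acid at this place would give a similar number. Going by these compounds, it is also open whether the hydroxy-to-amino step would be the same size with 2,4-dichlorophenyl on the sulfonyl sulfur.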